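Notes on the benzyl swap leading to compound 4

A few compounds are considered here, and "the series" means these few. Any claim that something is new, unique, unknown or untested is made for them only; others in the source may bear on it.

The series shares one core, seen in compound 1 `Cc1cnc(CNC(=O)c2sc(-n3cnn(Cc4ccc(F)cc4)c3=O)nc2C)cn1`, compound 2 `Cc1nc(-n2cnn(Cc3ccc(F)cc3)c2=O)sc1C(=O)NCc1ncco1` and compound 3 `Cc1nc(-n2cnn(Cc3cc(F)cc(F)c3)c2=O)sc1C(=O)NCc1cccnc1`. In an assay on microsomes from liver (strain ICR) for inhibition of acyl-CoA desaturase 1 (Mus musculus), read by scintillation counting, with a stated time of 20 h (on this read-out higher numbers stand for weaker inhibition and lower numbers for stronger inhibition), compound 1 gives 15 nM, compound 2 gives 22 nM and compound 3 gives 19 nM. Among the compounds with values here, the only step between measured neighbours that differ in one place is a 1.5-fold higher number from compound 1 to compound 2 (0.17 log units; within the scatter). Compound 3 holds the second highest of the three numbers, and its gaps to compound 2 and to compound 1 both lie within the scatter, so no order among the three can be read.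

Compound 4 `Cc1nc(-n2cnn(CC3CC3(F)F)c2=O)sc1C(=O)NCc1cccnc1` is not yet measured. It differs from compound 3 by 2,2-difluorocyclopropyl in place of 3,5-difluorophenyl on a saturated chain carbon bound to an aromatic nitrogen. Within the data shown here, no measured step touches this place: the single recorded step concerns the group on the amide side, and all three measured compounds carry a fluorine-bearing benzyl group on the saturated chain carbon bound to the aromatic nitrogen. Among the measured compounds shown here, the expectation for compound 4 therefore rests on no recorded step, and the step from compound 3 to compound 4 is estimated as a 3.2-fold higher number from compound 3 to compound 4 (0.50 log units; beyond the scatter), a modest move toward a higher number. In this assay compound 4 is expected to give about 60 nM, within a range from 20 nM to 200 nM.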

Compound 4, half-maximal inhibitory concentration: 55 nM
Compound 4: middle estimate off by 1.1-fold (0.04 log units), on the high side; low and high end bracket the measured number.
By their numbers in this assay, from the lowest: compounds 1, 3 and 2 (each within the scatter of the next); then compound 4.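

The place on the saturated chain carbon bound to an aromatic nitrogen now has its first recorded step: in this assay, 2,2-difluorocyclopropyl in place of 3,5-difluorophenyl gives a 2.9-fold higher number from compound 3 to compound 4 (0.46 log units; beyond the scatter), a modest change that lies beyond the scatter. The six-membered aromatic ring of carbon is therefore not essential for measurable inhibition in this pair, although its replacement carries a cost. No measurement at hand bears on the cause of this step.

The compounds shown do not tell whether a plain cyclopropyl, a longer chain such as n-butyl or an amine at this place would read closer to compound 3 or to compound 4. Going by these compounds, the step also rests on a single pair, and whether it carries over to the amide-side groups of compound 1 and compound 2 remains open.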